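Opening a cyclic amide into a chain-bearing ester

The source may report more compounds than this note shows. Statements on the series, on what has been measured and on what is new or still open speak of the compounds shown alone.

Compound 3 `O=C(CN1CN(c2ccccc2)C2(CCN(C(=O)c3ccc(C4CCCCC4)cc3)CC2)C1=O)N1CCCCC1` gives 1100 nM in an assay on HEK293 cells for displacement of a labelled ligand from NPC1-like intracellular cholesterol transporter 1 (Homo sapiens) (a higher number here means a weaker inhibitor, a lower number a stronger inhibitor), the lowest of the two numbers reported so far. Among the measured compounds shown here, compound 2 `CC(C)(C)OC(=O)NCC1CCCN(C(=O)CN2CN(c3ccccc3)C3(CCN(C(=O)c4ccc(C5CCCCC5)cc4)CC3)C2=O)C1` gives 3800 nM, and the step of a 3.5-fold lower number from compound 2 to compound 3 (0.54 log units; beyond the scatter) is the only measured step; compound 1 `CCc1nn(CC)c(C2CCN(C(=O)CN3CN(c4ccccc4)C4(CCN(C(=O)c5ccc(C6CCCCC6)cc5)CC4)C3=O)CC2)c1C` has "not determined" (no result reported) in this assay. Compound 4 `COC(=O)CCNC(=O)CN1CN(c2ccccc2)C2(CCN(C(=O)c3ccc(C4CCCCC4)cc3)CC2)C1=O` differs from compound 3 as follows: (2-(methoxycarbonyl)ethyl)amino in place of piperidin-1-yl on a carbonyl carbon. For the measured compounds named here, no measured step changes the piperidin-1-yl itself, so the one step bears only loosely on this change; it shows that altering this end of the molecule moves this assay modestly. Compound 4 is therefore expected to show a modest rise, a 2.0-fold higher number from compound 3 to compound 4 (0.30 log units; within the scatter), with an estimate of 2200 nM and a range from 700 nM to 7000 nM.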

Compound 4, half-maximal inhibitory concentration: 12900 nM
Estimate against measurement, compound 4: 5.9-fold (0.77 log units) below, and the stated range ends below it.
By their numbers in this assay, from the lowest: compound 3; then compound 2; then compound 4.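

In this assay, among the compounds shown here, (2-(methoxycarbonyl)ethyl)amino in place of piperidin-1-yl on the carbonyl carbon gives a 12-fold higher number from compound 3 to compound 4 (1.07 log units; beyond the scatter), so this position can move the number far more than the one earlier step showed. For the compounds shown here, compound 4 is the first measured compound here without a ring at this carbonyl carbon, and the change also adds a hydrogen-bond donor and hydrogen-bond acceptors. No measurement bears on what lies behind the step. The compounds shown do not separate the loss of the ring from the arrival of the ester chain. A carboxylic acid in place of the methyl ester, or a plain propylamino group, would leave these questions less entangled.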